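This account rests on a few compounds, and the source may have more. Where it says the series, first, only, none or still open, it means among the compounds named here.

Among the measured compounds shown here, compound 3, `COc1ccc(Nc2nc(/C=C/c3cc(OC)c(OC)c(OC)c3)nc3ccsc23)cc1`, is the only member of the set with a number in a functional assay on L02 cells (Homo sapiens) for inhibition, read by Griess assay, with stated times of 1 h and 24 h; a higher number here means a weaker inhibitor, a lower number a stronger inhibitor: in this assay compound 3 gives 279000 nM. Compound 1, `CN(C)c1nc(/C=C/c2ccccc2)nc2ccsc12`, reaches only a limit of the assay, since in this assay compound 1 gives > 1000000 nM. Compound 2, `CNc1nc(/C=C/c2cc(OC)c(OC)c(OC)c2)nc2ccsc12`, likewise stops at a limit, as in this assay compound 2 gives > 1000000 nM. Two of the three results therefore sit at the limit of > 1000000 nM in this assay, at which 2 of the 3 values shown sit, which leaves compound 3 as the lone fixed point.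

Compound 4, `COc1cc(/C=C/c2nc(NCc3ccccc3Cl)c3sccc3n2)cc(OC)c1OC`, differs from compound 3 in one place: 2-chlorobenzyl in place of 4-methoxyphenyl on a nitrogen on an aromatic ring. For the measured compounds named here, the one measured step that touches the same nitrogen is an at least 3.5-fold lower number from compound 2 to compound 3 (0.55 log units; beyond the scatter), where a larger aromatic group replaced a small alkyl. Going by the values given here, the move now is from one ring-bearing group to another of the same size, so that step offers only weak guidance, and no measured pair speaks to exchanging a methoxy for a chlorine or inserting a methylene.

The expectation is therefore a step of about a 1.1-fold lower number from compound 3 to compound 4 (0.05 log units; within the scatter) from compound 3 to compound 4, which lies within the scatter. Compound 4 is estimated at 250000 nM, in the range 80000 nM to 1000000 nM, with a real chance that the assay again reports only a limit.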

Compound 4, half-maximal inhibitory concentration: > 1000000 nM
Compound 4 gave a limit, no number (the forecaster's own chance of this, stated with the estimate: 30%); middle value at least 4.0-fold (0.60 log units) from the limit.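

Exchanging 4-methoxyphenyl for 2-chlorobenzyl on the nitrogen gives an at least 3.5-fold higher number from compound 3 to compound 4 (0.55 log units; beyond the scatter) in this assay, so two groups with the same count of heavy atoms, each with one six-membered aromatic ring of carbon only, are not interchangeable at this position. The earlier step showed only that 4-methoxyphenyl gives a lower number than methyl, whereas this result shows that a ring-bearing group on this nitrogen does not by itself secure a measurable value. Compound 4 reports only a limit of the assay, as does compound 2, so the step between those two compounds cannot be read, and the set now rests largely on limits: the limit of > 1000000 nM in this assay, at which 3 of the 4 values shown sit.

The change carries two differences at once, the added methylene and the chlorine in place of methoxy, and no compound shown separates them, as 4-methoxybenzyl or 2-chlorophenyl on this nitrogen would. Among the compounds shown here, compound 3 remains the only compound with a number, at 279000 nM, so it stays open whether other groups on its phenyl ring, such as hydroxy or dimethylamino in place of methoxy, would lower that number or lose it.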